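Swapping amino for nitro on a potent compound

The compounds below may be only part of what the source reports. "The series", "measured", "known", "first", "only" and "open" are said of these compounds alone.

Measured in a functional assay on A549 cells (Homo sapiens) for antiproliferative activity, read by MTT assay, with a stated time of 48 h; a higher number here means a weaker inhibitor, a lower number a stronger inhibitor:
- compound 1 `COc1ccc2c(/C=C/C(=O)c3cc(N)c(OC)c(OC)c3)cn(C)c2c1`: 106 nM
- compound 2 `COc1cc(C(=O)/C=C/c2c[nH]c3ccccc23)cc(SC)c1OC`: 152 nM
- compound 3 `COc1cc(C(=O)/C=C/c2cn(C)c3ccccc23)cc(N)c1OC`: 498 nM

Compound 1 sits at the low end of these three values, the strong end of this assay. It lies within the scatter of compound 2, and compound 3 stands clearly higher.

The next compound is compound 4 `COc1ccc2c(/C=C/C(=O)c3cc(OC)c(OC)c([N+](=O)[O-])c3)cn(C)c2c1`, which has nitro in place of amino on an aromatic carbon. Among the compounds with values here, no measured step makes this swap. Within the data shown here, the only measured single-place step is a 4.7-fold higher number from compound 1 to compound 3 (0.67 log units; beyond the scatter), with hydrogen in place of methoxy on an aromatic carbon. Among the measured compounds shown here, that step leaves the amino group untouched, so it shows only that one change on this core can move the number by a modest amount. Compound 2 has no amino group and gives 152 nM, but it differs from compound 1 in more than one place, so it cannot isolate the swap.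

Starting from the low end of the set, a modest move toward a higher number seems more likely than a further drop, though this is a weakly supported expectation. The expected change is a 4.7-fold higher number from compound 1 to compound 4 (0.67 log units; beyond the scatter). For compound 4 the estimated value is 500 nM, with an expected range from 120 nM to 3000 nM.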

Compound 4, half-maximal inhibitory concentration: 1020 nM
Compound 4: middle estimate off by 2.0-fold (0.31 log units), on the low side, and the stated range covers the measured number.
By their numbers in this assay, from the lowest: compounds 1 and 2 (each within the scatter of the next); then compound 3; then compound 4.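

In this assay, the aromatic carbon ortho to a methoxy group and meta to a large group proves sensitive to what it carries: putting nitro in place of amino there gives a 9.6-fold higher number from compound 1 to compound 4 (0.98 log units; beyond the scatter). Within the data shown here, this is the first direct look at the amino group itself, and on the core of compound 1 the swap moves the number well past the scatter, towards a weaker inhibitor. The change alters several things at once, replacing 1 heavy atom with 3 and a group with 1 hydrogen-bond donor with one with 0 hydrogen-bond donors, and no measurement here separates these differences or explains the loss.

The compounds shown leave open whether the loss comes from removing amino or from introducing nitro, a question that a plain hydrogen, a hydroxyl group or an acetamide at the same carbon could help to settle. Going by these compounds, it also remains open whether the same swap would have a similar effect on compound 3, which has hydrogen in place of methoxy on an aromatic carbon.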